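The source may report more compounds than this note shows. Statements on the series, on what has been measured and on what is new or still open speak of the compounds shown alone.

Three compounds of one shared core have been examined in a functional assay on HCT-15 cells (Homo sapiens) for cytotoxicity, read by CCK-8 assay and cell counting, with a stated time of 2 days; a lower number here means a stronger inhibitor, a higher number a weaker inhibitor. For the measured compounds named here, compound 1 `Oc1ccc(-c2cc(-c3ccco3)nc(-c3ccccc3Cl)c2)cc1` gives 5460 nM in this assay, the lowest of the two numbers so far, though the gap to its nearest neighbour lies within the scatter. Going by the values given here, compound 3 `Oc1ccc(-c2cc(-c3ccc(Cl)cc3)nc(-c3ccco3)c2)cc1` gives 7020 nM in this assay, and the single step between measured compounds, a 1.3-fold higher number from compound 1 to compound 3 (0.11 log units; within the scatter), swaps a 4-chlorophenyl for a 2-chlorophenyl group. Compound 2 `Oc1ccc(-c2cc(-c3ccncc3)nc(-c3ccccc3Cl)c2)cc1` gives "not determined" (no result reported) in this assay, so no number is available for it.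

Compound 4 `Oc1cccc(-c2cc(-c3ccco3)nc(-c3ccccc3Cl)c2)c1` is the next to be measured. It differs from compound 1 by 3-hydroxyphenyl in place of 4-hydroxyphenyl on an aromatic carbon. Among the compounds with values here, no measured step touches this part of the molecule: the one step recorded concerns the chlorophenyl group, not the hydroxyphenyl group, and it stayed within the scatter. Without a comparable precedent, the change from compound 1 to compound 4 is expected to yield a step of a 1.2-fold higher number from compound 1 to compound 4 (0.08 log units; within the scatter), that is, no shift clearly beyond the scatter. Compound 4 is therefore estimated at 6500 nM in this assay, with a range from 2500 nM to 17000 nM.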

Compound 4, half-maximal inhibitory concentration: 2230 nM
Estimate against measurement, compound 4: 2.9-fold (0.46 log units) above; the whole stated range lies above it.
By their numbers in this assay, from the lowest: compound 4; then compounds 1 and 3 (each within the scatter of the next).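

Swapping 4-hydroxyphenyl for 3-hydroxyphenyl in this assay gives a 2.4-fold lower number from compound 1 to compound 4 (0.39 log units; beyond the scatter), a modest change but the first step in this small series to lie beyond the scatter. The two compounds contain the same atoms joined differently, so the place of the hydroxyl group on this phenyl ring, itself attached opposite the ring nitrogen, matters to the read-out, whereas the earlier step, which moved the chlorine and exchanged the positions of two groups, did not stand out from the scatter. No available evidence bears on why the 3-hydroxyphenyl compound gives the lower number.

From the compounds shown here alone, it remains open whether 3-aminophenyl or 3-methoxyphenyl at this place would match 3-hydroxyphenyl. Also open, going by these compounds, is whether the same swap would shift the number in the same direction on the core of compound 3.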